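Swapping a Pyrazole for a Furan on an Inactive Amide

A few compounds are considered here, and "the series" means these few. Any claim that something is new, unique, unknown or untested is made for them only; others in the source may bear on it.

Compound 2 `CCN(Cc1cc[nH]n1)C(=O)COc1ccc(C)cc1` is the starting point. In an assay on HEK293 cells for agonist activity at transient receptor potential cation channel subfamily M member 8 (Homo sapiens), read by fluorescence and calcium flux, with a stated time of 15 min (on this read-out higher numbers stand for an effect only at larger amounts of compound and lower numbers for an effect already at smaller amounts), compound 2 gives "not active" (no number reported), so no number marks where it stands; on the numbers shown it sits apart from the two compounds that do give values. Compound 1 `Cc1ccc(OCC(=O)N(Cc2cccs2)c2ccn(C)n2)cc1` gives 855 nM in this assay, and compound 3 `Cc1ccc(OCC(=O)N(Cc2cccs2)CC(C)C)cc1` gives 900 nM. For the measured compounds named here, the one step between measured compounds, a 1.1-fold higher number from compound 1 to compound 3 (0.02 log units; within the scatter), changes only what sits on the amide-type nitrogen and leaves the group on the saturated chain carbon untouched, so it does not speak directly to the change considered here.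

Compound 4 `CCN(Cc1ccco1)C(=O)COc1ccc(C)cc1` differs from compound 2 as follows: furan-2-yl in place of 1H-pyrazol-3-yl on a saturated chain carbon bound to an amide-type nitrogen. The group that enters has no hydrogen-bond donor, which brings compound 4 closer in that respect to compound 1 and compound 3, both of which act in this assay at similar values. Going by the values given here, no measured step covers the swap itself, and compound 2 gives no number to step from, so direction can only be guessed from that resemblance. Compound 4 is therefore expected to act in this assay, though only at larger amounts than compound 1 or compound 3, with an estimate of 2500 nM and a wide range from 600 nM to 12000 nM, and a sizable chance that no number is found at all.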

Compound 4, half-maximal effective concentration: 489 nM
Estimate against measurement, compound 4: 5.1-fold (0.71 log units) above, outside the stated range (below it).
By their numbers in this assay, from the lowest: compounds 4, 1 and 3 (each within the scatter of the next).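

In this assay, for the compounds shown here, compound 2 gives "not active" (no number reported) and so no new step to compound 4 can be read. Nothing shown offers a reason for the activity of compound 4. The compounds shown leave open how much furan-2-yl in place of 1H-pyrazol-3-yl changes the value, since only one side of that swap carries a number.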